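Amine exchange in a dog oral bioavailability series

A few compounds are considered here, and "the series" means these few. Any claim that something is new, unique, unknown or untested is made for them only; others in the source may bear on it.

Measured compounds:
compound 1 `Nc1noc2ccc(-n3nc(C(F)(F)F)c4c3C(=O)N(c3ccc(-c5ccccc5CN5CC[C@@H](O)C5)cc3F)CC4)cc12`: 81%
compound 2 `CN(C)Cc1ccccc1-c1ccc(N2CCc3c(C(F)(F)F)nn(-c4ccc5onc(N)c5c4)c3C2=O)cc1`: 50%
compound 3 `CN(C)Cc1ccccc1-c1ccc(N2CCc3c(C(F)(F)F)nn(-c4ccc5onc(N)c5c4)c3C2=O)c(F)c1`: 83%

In an in vivo ADME assay on the whole organism for pharmacokinetics, with Canis familiaris (Canis lupus familiaris) as the target (a higher number here means that a larger share of the oral dose reaches the circulation, a lower number that a smaller share of the oral dose reaches the circulation), compound 2 gives 50%, the lowest of the three numbers; compound 1 gives 81% and compound 3 gives 83%, each beyond the scatter above compound 2.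

Compound 4 `Nc1noc2ccc(-n3nc(C(F)(F)F)c4c3C(=O)N(c3ccc(-c5ccccc5CN5CCC(O)CC5)cc3)CC4)cc12` differs from compound 2 in one place: 4-hydroxypiperidin-1-yl in place of dimethylamino on a saturated chain carbon bound to an aromatic carbon. The step that bears on this exchange is a number 2 percentage points higher from compound 1 to compound 3 (within the scatter), an amine swap at the same place, which stayed within the scatter. The step of a number 33 percentage points higher from compound 2 to compound 3 (beyond the scatter) concerns a different place and does not speak to the present change. No step beyond the scatter is therefore expected in this assay; the expected change is no change at the digits printed from compound 2 to compound 4 (within the scatter). Compound 4 is estimated at 50%, with a range of 30% to 70%.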

Compound 4, oral bioavailability: 102%
Compound 4: the middle estimate sits 52 percentage points below what was measured, outside the stated range (above it).
By their numbers in this assay, from the lowest: compound 2; then compounds 1 and 3 (each within the scatter of the next); then compound 4.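

In this assay the amine at the saturated chain carbon bound to an aromatic carbon is not a neutral choice: 4-hydroxypiperidin-1-yl in place of dimethylamino gives a number 52 percentage points higher from compound 2 to compound 4 (beyond the scatter), while the swap between the two fluoro-bearing compounds gave a number 2 percentage points higher from compound 1 to compound 3 (within the scatter). A large step at this place therefore appears in the series without fluoro, so the outcome of an amine exchange here does not carry over between the two pairs. No data at hand bear on the origin of this step.

Open, on these data alone, is whether the ring or the hydroxy group of 4-hydroxypiperidin-1-yl carries the step; piperidin-1-yl or morpholin-4-yl at this place would separate the two. Also open, as far as these compounds go, is what fluoro would do on compound 4.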